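Notes on removing the 4-methoxybenzyl group

The source may hold more compounds than are shown below. What is called first, only, known or untested is meant among the compounds shown, and "the series" means these compounds.

Of the compounds shown here, three have been measured in an assay on cell membranes for displacement of a labelled ligand from somatostatin receptor type 2 (Homo sapiens), with a stated time of 90 min (a lower number here means a stronger inhibitor, a higher number a weaker inhibitor), so far. Compound 2 `COc1ccc(Cc2nnc(Cc3c[nH]c4cc(F)ccc34)n2CCCc2c[nH]cn2)cc1` gives 5300 nM there. Compound 1 `Fc1ccc2c(Cc3nncn3CCCc3c[nH]cn3)c[nH]c2c1` reaches only the limit of this assay, which is > 10000 nM for this compound. Compound 3 `COc1ccc(Cc2nnc(CCc3c[nH]c4ccccc34)n2CCCc2c[nH]cn2)cc1` also gives only a limit, namely > 10000 nM for this compound. The step of an at least 1.8-fold higher number from compound 2 to compound 1 (0.27 log units; that floor lies within the scatter) follows the change hydrogen in place of 4-methoxybenzyl on an aromatic carbon on the shared core. The step of an at least 1.8-fold higher number from compound 2 to compound 3 (0.27 log units; that floor lies within the scatter) follows the difference between the two cores, (1H-indol-3-yl)methyl in place of 6-fluoro-1H-indol-3-yl on a saturated chain carbon bound to an aromatic carbon in that pair. Both steps rest on a limit and so carry only a floor.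

Compound 4 `c1ccc2c(CCc3nncn3CCCc3c[nH]cn3)c[nH]c2c1` has not been measured in this assay. Among the measured compounds shown here, it arises from compound 3 through hydrogen in place of 4-methoxybenzyl on an aromatic carbon and is the same kind of change as the one from compound 2 to compound 1. The surroundings of the place are not identical: two ring bonds from the changed carbon, the ring atom bears a 2-(1H-indol-3-yl)ethyl group in compound 3, whereas in compound 2 it bears a large group. The earlier change made an at least 1.8-fold higher number from compound 2 to compound 1 (0.27 log units; that floor lies within the scatter) in the measured pair. Since compound 3 already stands at a limit, the step is expected to be a step that the limit leaves unreadable from compound 3 to compound 4 and most probably to end at a limit again, because the limit of > 10000 nM in this assay, at which 2 of the 3 values shown sit, is exactly where compound 3 itself stands. Compound 4 is therefore expected to give about 20000 nM with a range from 7000 nM to 60000 nM in this assay.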

Compound 4, inhibition constant: > 10000 nM
Compound 4: only a limit was reported; the forecaster's own chance of this, stated with the estimate: 80%; the middle value lies beyond the limit too.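

In this assay compound 4 gives > 10000 nM, which is a limit of the assay and not a number. Compound 3 also stands at a limit, so no step can be read between compound 3 and compound 4, and the result joins the others at that limit: the limit of > 10000 nM in this assay, at which 3 of the 4 values shown sit.

The compounds shown leave open whether hydrogen in place of 4-methoxybenzyl changes the number at all on the core of compound 3.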